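The source may report more compounds than this note shows. Statements on the series, on what has been measured and on what is new or still open speak of the compounds shown alone.

Working notes on cytotoxicity in an ADME assay on BaF3 cells (Mus musculus) for cytotoxicity; a lower number here means that less compound is needed, a higher number that more compound is needed for the effect.

Compound 1 `FC(F)(F)Oc1ccc(Nc2cc(-c3cn[nH]c3)ncn2)cc1` is the starting point of this step. In this assay compound 1 gives > 10000 nM, which is a limit of the assay rather than a number. Compound 2 `CCNC(=O)c1cc2c(Nc3ccc(OC(F)(F)F)cc3)ncnc2s1` sits on a different core. In this assay compound 2 gives > 10000 nM, likewise a limit. Compound 3 `O=C(c1cc2c(Nc3ccc(OC(F)(F)F)cc3)ncnc2s1)N1CCC(O)CC1` shares the core of compound 2. In this assay compound 3 gives > 10000 nM, again a limit. For the measured compounds named here, the only measured step between compounds differing in one place is a step that the two limits leave unreadable from compound 2 to compound 3, 4-hydroxypiperidin-1-yl in place of ethylamino on a carbonyl carbon, and its size is not readable. Compound 1 therefore stands with the other two compounds at the limit of > 10000 nM in this assay, at which 3 of the 3 values shown sit, with no number separating any of them.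

Compound 4 `FC(F)(F)Oc1ccc(Nc2cc(-c3cccc4[nH]ccc34)ncn2)cc1` differs from compound 1 by 1H-indol-4-yl in place of 1H-pyrazol-4-yl on an aromatic carbon. Going by the values given here, no measured step bears on this change: the single recorded step lies on the other core and is unreadable, and no pair on the core of compound 1 has been measured. No step beyond the scatter is expected in this assay in either direction. The step expected from this change is estimated as a step that the limit leaves unreadable from compound 1 to compound 4, resting only on the three limits. For compound 4 the expected value in this assay is 15000 nM, estimated between 5000 nM and 40000 nM, with a strong chance that only a limit is reported again.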

Compound 4, half-maximal effective concentration: 3790 nM
The estimate for compound 4 lay 4.0-fold (0.60 log units) above the measured number, outside the stated range (below it).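

For the compounds shown here, at this aromatic carbon on the core of compound 1, 1H-indol-4-yl in place of 1H-pyrazol-4-yl gives the only readable step so far in this assay, with an at least 2.6-fold lower number from compound 1 to compound 4 (0.42 log units; beyond the scatter). The step shows that this position can move the number beyond the scatter, which the unreadable step on the other core could not show. Its true size stays open on one side, and compound 4 is the only compound shown with a number rather than a limit: the limit of > 10000 nM in this assay, at which 3 of the 4 values shown sit.

The change adds a six-membered aromatic ring of carbon only and replaces a five-membered aromatic ring with 2 hetero atoms by one with 1 hetero atom, and the compounds shown do not separate these two differences. From the compounds shown here alone, whether a plain phenyl group or a ring carrying an amine or a carboxylic acid at this carbon would also lower the number remains open, as does whether 1H-indol-4-yl would have the same effect on a different core.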